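A few compounds are considered here, and "the series" means these few. Any claim that something is new, unique, unknown or untested is made for them only; others in the source may bear on it.

Compound 1 `Nc1nc(N)c2c(-c3ccsc3)cn([C@@H]3O[C@H](CO)[C@@H](O)[C@H]3O)c2n1` in a functional assay on HCT-116 cells (Homo sapiens), read by MTT assay, with a stated time of 72 h (a higher number here means a weaker inhibitor, a lower number a stronger inhibitor), gives only the limit > 20000 nM, so compound 1 stands at the limit rather than at a number. Compound 3 `Cc1nc(N)c2c(-c3ccsc3)cn([C@@H]3O[C@H](CO)[C@@H](O)[C@H]3O)c2n1` also returns the limit > 20000 nM. The step that the two limits leave unreadable from compound 1 to compound 3 is therefore unreadable, as the limit of > 20000 nM in this assay, at which 2 of the 3 values shown sit, shows. Compound 2 `Nc1nc2c(c(-c3ccoc3)cn2[C@@H]2O[C@H](CO)[C@@H](O)[C@H]2O)c(=O)[nH]1`, which carries furan-3-yl on a different core, gives 17600 nM. Compound 4 `Nc1nc(N)c2c(-c3ccoc3)cn([C@@H]3O[C@H](CO)[C@@H](O)[C@H]3O)c2n1` differs from compound 1 by furan-3-yl in place of thiophen-3-yl on an aromatic carbon. Among the compounds with values here, no measured step exchanges thiophen-3-yl for furan-3-yl on the shared core, so the only guide is compound 2 with 17600 nM. The step that the limit leaves unreadable from compound 1 to compound 4 is expected to be small or none beyond the scatter, with compound 4 most likely at the limit again. Compound 4 is estimated at 25000 nM, range 10000 nM to 60000 nM.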

Compound 4, half-maximal inhibitory concentration: > 20000 nM
Compound 4: a limit, no number (the forecaster's own chance of this, stated with the estimate: 65%); the middle value lies beyond the limit too.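

Compound 1 and compound 4 both return a limit in this assay, so no step can be read for furan-3-yl in place of thiophen-3-yl: the limit of > 20000 nM in this assay, at which 3 of the 4 values shown sit. As far as these compounds go, how these two groups compare on the shared core remains open.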